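A few compounds are considered here, and "the series" means these few. Any claim that something is new, unique, unknown or untested is made for them only; others in the source may bear on it.

Measured in a functional assay on CCRF-CEM cells (Homo sapiens) for antiproliferative activity, with a stated time of 72 h; on this read-out lower numbers stand for stronger inhibition and higher numbers for weaker inhibition:
compound 1, `CSc1cnc2ccccc2c1[Se]CC#CCO`: 0.5 ug/mL
compound 2, `OCC#CCSc1cnc2ccccc2c1SCC#CCCl`: 3.3 ug/mL
compound 3, `CSc1cnc2ccccc2c1SCC#CCOC(=O)/C=C/c1ccccc1`: 18.1 ug/mL

Compound 3 gives the highest of these three numbers; compound 2 stands nearer to it and compound 1 furthest away, both gaps lying beyond the scatter. Compound 4, `C#CCSc1cnc2ccccc2c1SCC#CCOC(=O)/C=C/c1ccccc1`, differs from compound 3 by a single change: ethynyl in place of hydrogen on a saturated chain carbon bound to a sulfur. Among the compounds with values here, no pair of measured compounds shows this exact change, so its effect cannot be read from the data. Given that compound 2, which carries an alkynyl chain on its sulfur, gives 3.3 ug/mL, the step of a 1.5-fold lower number from compound 3 to compound 4 (0.18 log units; within the scatter) is expected to be small, toward a somewhat lower number or none beyond the scatter. Compound 4 is therefore estimated at 12 ug/mL, within 4 ug/mL to 40 ug/mL.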

Compound 4, concentration for 50% inhibition: 50.9 ug/mL
For compound 4 the middle estimate is 4.2-fold (0.63 log units) below the measured one; measured number above the stated range.
By their numbers in this assay, from the lowest: compound 1; then compound 2; then compound 3; then compound 4.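

Going from methyl to propargyl on the sulfur, in this assay, gives a 2.8-fold higher number from compound 3 to compound 4 (0.45 log units; beyond the scatter). The position therefore responds to this change, and the added ethynyl moves the number toward weaker inhibition rather than leaving it unchanged. No available evidence bears on why this step occurs.

From the compounds shown here alone, whether a longer saturated chain, an amine or a carboxylic acid at this place would shift the number further remains open. So does whether ethynyl has the same effect when the other chain on the shared core is different.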